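This account rests on a few compounds, and the source may have more. Where it says the series, first, only, none or still open, it means among the compounds named here.

Compound 1, `c1ccc(OCc2nc3c(OCCCN4CCCCC4)cccc3n2CCCC2CCN(CCCN3CCCCC3)CC2)cc1`, gives 0.106 nM in an in vitro assay on AV12 cells for binding affinity to Neuropeptide Y receptor type 1 (Homo sapiens); a higher number here means a weaker inhibitor, a lower number a stronger inhibitor.
Compound 2, `CN1CCC(CCCn2c(COc3ccccc3)nc3c(OCCCN4CCCCC4)cccc32)CC1`, gives 1.62 nM in this assay.

Of the two numbers measured, compound 2 stands highest, so compound 2 is the weaker of the two in this assay. Going by the values given here, the one measured step links the pair: a 15-fold higher number from compound 1 to compound 2 (1.18 log units; beyond the scatter). That step shows that, at this place, taking a substituent down to a bare hydrogen weakened binding by a large and clear margin, so the reverse move, putting a group back onto that carbon, should work in the other direction.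

Compound 3, `c1ccc(CCCN2CCC(CCCn3c(COc4ccccc4)nc4c(OCCCN5CCCCC5)cccc43)CC2)cc1`, is the unmeasured compound. It differs from compound 2 in one place: phenethyl in place of hydrogen on a saturated chain carbon bound to an amine nitrogen in a ring. The entering group is not the one that was lost between compound 1 and compound 2, so the earlier step bears on compound 3 only as a pointer to direction and rough size; a regain of some but perhaps not all of the lost binding is the expectation. Compound 3 is therefore expected to give a lower number than compound 2, a step of about a 3.2-fold lower number from compound 2 to compound 3 (0.51 log units; beyond the scatter), and its estimated value in this assay is 0.5 nM, with a range from 0.15 nM to 2 nM.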

Compound 3, inhibition constant: 0.361 nM
Estimate against measurement, compound 3: 1.4-fold (0.14 log units) above; measured number inside the range.
By their numbers in this assay, from the lowest: compound 1; then compound 3; then compound 2.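

The step of a 4.5-fold lower number from compound 2 to compound 3 (0.65 log units; beyond the scatter) in this assay shows that this saturated chain carbon bound to an amine nitrogen in a ring can carry phenethyl, a group of carbon only with one six-membered aromatic ring, and still regain a clear part of the binding seen without the 2-(piperidin-1-yl)ethyl group of compound 1, so among these three compounds the regain does not depend on a second amine nitrogen in the added group. The step of a 3.4-fold higher number from compound 1 to compound 3 (0.53 log units; beyond the scatter) shows, however, that phenyl and piperidin-1-yl are not equivalent at the far side of this substituent, since the move from the amine-bearing group to the all-carbon one costs binding by a margin beyond the usual scatter. No other measurement bears on this result, so the data offer no explanation for either step.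

The compounds shown leave open whether a morpholine ring or an open-chain dimethylamino group would match piperidin-1-yl at this place, and whether a carboxylic acid would be tolerated there. They also leave open how a shorter or longer chain, or a fluorine or methoxy group on the phenyl ring of compound 3, would change binding.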